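Swapping the five-membered heteroaryl on the aminothienopyrimidine core

A few compounds are considered here, and "the series" means these few. Any claim that something is new, unique, unknown or untested is made for them only; others in the source may bear on it.

Of the compounds shown here, two sharing one core have been measured. In a functional assay on CHO-K1 cells for antagonist activity at adenosine receptor A1 (Homo sapiens), read by a beta-galactosidase reporter and cAMP accumulation, with stated times of 15 min and 6 h (a lower number here means a stronger inhibitor, a higher number a weaker inhibitor), compound 1 `CCc1ccc(-c2nc(N)c3cc(Cc4ccccc4)sc3n2)o1` gives 223 nM. Compound 2 `Cc1nc(-c2nc(N)c3cc(Cc4ccccc4)sc3n2)cs1` gives 263 nM in this assay. Among the measured compounds shown here, the only measured step, a 1.2-fold higher number from compound 1 to compound 2 (0.07 log units; within the scatter), is a swap of one five-membered heteroaryl for another at the same position. On the numbers shown, compound 2 stands highest of the two, but its only neighbour, compound 1, lies within the scatter of it, so no order between them can be claimed.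

Compound 3 `Cn1cnc(-c2nc(N)c3cc(Cc4ccccc4)sc3n2)c1` is not yet measured. It differs from compound 2 by 1-methyl-1H-imidazol-4-yl in place of 2-methyl-1,3-thiazol-4-yl on an aromatic carbon. For the measured compounds named here, the one step that bears on this is a 1.2-fold higher number from compound 1 to compound 2 (0.07 log units; within the scatter), since it too replaced the five-membered heteroaryl on the same aromatic carbon, and it was within the scatter. Compound 3 is therefore expected to stay close to compound 2, with a step of a 1.2-fold higher number from compound 2 to compound 3 (0.09 log units; within the scatter) that is not expected to exceed the scatter in either direction. The estimated value for compound 3 in this assay is 320 nM, in a range from 110 nM to 950 nM.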

Compound 3, inhibition constant: 2330 nM
Estimate against measurement, compound 3: 7.3-fold (0.86 log units) below; the measured number lies above the stated range.
By their numbers in this assay, from the lowest: compounds 1 and 2 (each within the scatter of the next); then compound 3.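

The change to 1-methyl-1H-imidazol-4-yl on the aromatic carbon between two ring nitrogen atoms gives an 8.9-fold higher number from compound 2 to compound 3 (0.95 log units; beyond the scatter) in this assay, so this position does respond to the choice of five-membered heteroaryl, which the earlier swap within the scatter could not show. The group that leaves and the group that enters have the same count of heavy atoms, hydrogen-bond donors and hydrogen-bond acceptors, and each is one five-membered aromatic ring with 2 hetero atoms and no net charge, so these matching counts did not keep the number in place. Against 5-ethylfuran-2-yl the same group gives a 10-fold higher number from compound 1 to compound 3 (1.02 log units; beyond the scatter), which sets compound 3 apart from the pair of compound 1 and compound 2.

Nothing given here accounts for this difference. From the compounds shown here alone, the three compounds do not separate the exchange of sulfur for nitrogen from the different place of the methyl group, and it remains open whether an oxazole, a thiophene or a phenyl ring on this carbon would fall with compound 1 and compound 2 or with compound 3.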